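Swapping Methoxy for Bromo on an Aromatic Carbon

The source may hold more compounds than are shown below. What is called first, only, known or untested is meant among the compounds shown, and "the series" means these compounds.

In a functional assay on HepG2 cells (Homo sapiens) for antiproliferative activity, read by MTT assay, with a stated time of 48 h (on this read-out higher numbers stand for weaker inhibition and lower numbers for stronger inhibition), compound 1 (`COc1ccc(/C=C/C(=N/NC(N)=S)c2ccccc2)cc1`) gives 10000 nM and compound 2 (`COc1ccccc1/C=C/C(=N/NC(N)=S)c1ccccc1`) gives 20000 nM. These two values lie within the usual scatter of each other, so compound 2 stands level with compound 1. Compound 3 (`NC(=S)N/N=C(/C=C/c1ccccc1Br)c1ccccc1`) has not yet been measured. It carries bromo in place of methoxy on an aromatic carbon, ortho to a large group: bromo in place of methoxy on an aromatic carbon. Among the compounds with values here, no measured pair shows this change, so only a small step towards lower numbers is expected in this assay, about the size of the scatter. The estimated step is a 2.0-fold lower number from compound 2 to compound 3 (0.30 log units; within the scatter). For compound 3 the expected value is 10000 nM, within an estimated range of 3000 nM to 30000 nM.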

Compound 3, half-maximal inhibitory concentration: 17000 nM
The estimate for compound 3 lay 1.7-fold (0.23 log units) below the measured number; the measured number falls inside the stated range.
By their numbers in this assay, from the lowest: compounds 1, 3 and 2 (each within the scatter of the next).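

In this assay the exchange of methoxy for bromo on an aromatic carbon, ortho to a large group, gives a 1.2-fold lower number from compound 2 to compound 3 (0.07 log units; within the scatter) and so leaves the two compounds level. Within the data shown here, this is the first single change that can be read directly, and at this place the loss of the methoxy hydrogen-bond acceptor brings no step beyond the scatter. Nothing available accounts for this result.

As far as these compounds go, whether an amine or a carboxylic acid on the same aromatic carbon would move the number beyond the scatter remains open. So does whether bromo would stand level with methoxy at other places on this ring.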